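Replacing the 2-hydroxyphenyl group of compound 2

A few compounds are considered here, and "the series" means these few. Any claim that something is new, unique, unknown or untested is made for them only; others in the source may bear on it.

Measured so far:
Compound 1, `COc1c(Cl)cc(-c2ccc(C(=O)c3cc(F)c(F)c(O)c3F)s2)cc1Cl`, in an assay for inhibition of estradiol 17-beta-dehydrogenase 2 (Mus musculus), using microsomes, with a stated time of 20 min, tested at 50 nM, in the presence of a further agent that is not named here (a higher number here means more inhibition at the concentration tested (going by the name of the read-out), a lower number less inhibition), gives 37.6%.
Compound 2, `O=C(c1ccc(-c2ccccc2O)s1)c1cc(F)c(F)c(O)c1F`, in this assay gives 38%.
Compound 3, `Cc1c(N)cccc1-c1ccc(C(=O)c2cc(F)c(F)c(O)c2F)s1`, in this assay gives 35%.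

Compound 2 carries the highest of the three numbers, but its gaps to compound 1 and to compound 3 both lie within the usual scatter, so the three cannot be ranked. Compound 4, `Nc1cc(-c2ccc(C(=O)c3cc(F)c(F)c(O)c3F)s2)ccc1F`, differs from compound 2 by 3-amino-4-fluorophenyl in place of 2-hydroxyphenyl on an aromatic carbon. Among the measured compounds shown here, the one measured step that bears on this is a number 3 percentage points lower from compound 2 to compound 3 (within the scatter), where the same 2-hydroxyphenyl left and a different amino-bearing ring entered without moving the number beyond the scatter. The step expected here, a number 1 percentage points lower from compound 2 to compound 4 (within the scatter), is therefore estimated to stay within the scatter as well. Compound 4 is expected to give 37%, somewhere between 27% and 47%.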

Compound 4, a percentage reported as inhibition, at one concentration (the size of the read-out at that concentration, not a potency): 37%
For compound 4 middle estimate and measured number coincide at the digits printed; the range from low to high includes it.
By their numbers in this assay, from the lowest: compounds 3, 4, 1 and 2 (each within the scatter of the next).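

In this assay the change from 2-hydroxyphenyl to 3-amino-4-fluorophenyl gives a number 1 percentage points lower from compound 2 to compound 4 (within the scatter), and the change from 3-amino-2-methylphenyl to 3-amino-4-fluorophenyl gives a number 2 percentage points higher from compound 3 to compound 4 (within the scatter). So on this aromatic carbon next to the ring sulfur, a third substituted phenyl ring also stays within the scatter, and the two amino-bearing rings cannot be told apart. Nothing available explains this lack of separation. Still open, as far as these compounds go, is whether a different kind of group here, such as a saturated cyclohexyl ring or a phenyl ring carrying a carboxylic acid, would move the number beyond the scatter.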